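Methyl removed from the core of compound 2

A few compounds are considered here, and "the series" means these few. Any claim that something is new, unique, unknown or untested is made for them only; others in the source may bear on it.

Of the compounds shown here, three have been measured in a physicochemical assay for metabolic stability, read by HPLC, in phosphate buffer, at pH 7.4, tested at 10 uM; on this read-out lower numbers stand for a shorter-lived compound and higher numbers for a longer-lived compound. Compound 1 `Cc1ccccc1CNC(=O)n1c(N)nc2ccccc21` gives 0.167 h. Compound 2 `Cc1nc2ccccc2n1C(=O)NCCCCc1ccccc1` gives 0.117 h. Compound 3 `CCCCCCNC(=O)n1nnc2ccccc21` gives 0.283 h. Compound 2 stands at the low end of these three numbers; compound 1 lies within the scatter of it, so no order between those two is claimed, while compound 3 stands beyond the scatter on the higher side. Among the compounds with values here, no two of the measured compounds differ in a single place, so no measured single-point step is available.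

Compound 4 `O=C(NCCCCc1ccccc1)n1cnc2ccccc21` has not yet been measured in this assay. It differs from compound 2 by this change: hydrogen in place of methyl on an aromatic carbon. Nothing in the measured set shows what such a change does. The step from compound 2 to compound 4 in this assay is therefore expected to stay within the scatter, with no direction favoured. Compound 4 is estimated at 0.13 h, in the range 0.06 h to 0.3 h. The estimate implies a step of a 1.1-fold higher number from compound 2 to compound 4 (0.05 log units; within the scatter), expected to be small.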

Compound 4, half-life: 0.833 h
For compound 4 the middle estimate is 6.4-fold (0.81 log units) below the measured one, and the stated range ends below it.
By their numbers in this assay, from the lowest: compounds 2, 1 and 3 (each within the scatter of the next, the first and the last beyond it); then compound 4.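

Hydrogen in place of methyl, on an aromatic carbon between two ring nitrogen atoms, gives in this assay a 7.1-fold higher number from compound 2 to compound 4 (0.85 log units; beyond the scatter) and so marks this position as one that affects the half-life. The loss of a single carbon, with no ring, hydrogen-bond donor, hydrogen-bond acceptor or net charge changing, is enough for a step beyond the scatter while the rest of compound 2 stays the same. No supporting data bear on why the step arises.

Still open, from the compounds shown here alone, is whether the step is tied to methyl itself or whether another group at this place, such as ethyl or a chlorine atom, would also give a number well apart from that of compound 4. Also open, going by these compounds, is whether the step holds with a shorter chain in place of the one carrying the phenyl ring.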